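Swapping the aryl group on the saturated ring carbon

The source may report more compounds than this note shows. Statements on the series, on what has been measured and on what is new or still open speak of the compounds shown alone.

Compound 1 `CN1C(=O)C(C2CC2)N(C)c2nc(Nc3ccc(S(N)(=O)=O)cc3)ncc21`: 136 nM
Compound 2 `CN1CC(=O)N(C)c2cnc(Nc3ccc(S(N)(=O)=O)cc3)nc21`: 495 nM
Compound 3 `CN1C(=O)C(c2cccc(F)c2)N(C)c2nc(Nc3ccc(S(N)(=O)=O)cc3)ncc21`: 134 nM

These values come from an assay on Sf9 cells for inhibition of serine/threonine-protein kinase 4 (Homo sapiens), read by luminescence and ADP-Glo, with a stated time of 1 h, in the presence of a further agent that is not named here; a higher number here means a weaker inhibitor, a lower number a stronger inhibitor. Compound 3 has the lowest number of the three, although its gap to compound 1 is within the scatter, as a 1.0-fold lower number from compound 1 to compound 3 (0.01 log units; within the scatter) shows. Only compound 2 is clearly apart, by a 3.7-fold lower number from compound 2 to compound 3 (0.57 log units; beyond the scatter).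

Compound 4 `COc1ccccc1C1C(=O)N(C)c2cnc(Nc3ccc(S(N)(=O)=O)cc3)nc2N1C` carries 2-methoxyphenyl in place of 3-fluorophenyl on a saturated ring carbon. Among the measured compounds shown here, no measured step exchanges one aryl group for another; the steps that bear on it show only that a group on this carbon, whether cyclopropyl or 3-fluorophenyl, gives a lower number than hydrogen, by a 3.6-fold higher number from compound 1 to compound 2 (0.56 log units; beyond the scatter). Compound 4 is therefore expected to stay close to compound 3, with a step of a 1.2-fold higher number from compound 3 to compound 4 (0.08 log units; within the scatter). The estimate for compound 4 is 160 nM, ranging from 60 nM to 450 nM.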

Compound 4, half-maximal inhibitory concentration: 251 nM
The estimate for compound 4 lay 1.6-fold (0.20 log units) below the measured number; the range from low to high includes it.
By their numbers in this assay, from the lowest: compounds 3, 1, 4 and 2 (each within the scatter of the next, the first and the last beyond it).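

Exchanging one aryl group for another on this saturated ring carbon changes little (a 1.9-fold higher number from compound 3 to compound 4 (0.27 log units; within the scatter)), and the same holds against cyclopropyl (a 1.8-fold higher number from compound 1 to compound 4 (0.27 log units; within the scatter)). Unlike cyclopropyl and 3-fluorophenyl, however, 2-methoxyphenyl does not clearly separate from hydrogen (a 2.0-fold lower number from compound 2 to compound 4 (0.29 log units; within the scatter)), so compound 4 goes against the earlier pattern that a group on this carbon gives a clearly lower number than hydrogen. From the compounds shown here alone, whether an amine or a carboxylic acid on this carbon would behave like these groups remains open. Nothing available explains why these steps are as small as they are.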